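This account rests on a few compounds, and the source may have more. Where it says the series, first, only, none or still open, it means among the compounds named here.

Compound 1 `CC1=CC[C@H]2[C@H](CC[C@]2(C)O)C(C)(C)[C@@H]1CC[C@H]1[C@]2(C)CC[C@H](OC(=O)c3ccc(Cl)cc3)C(C)(C)O[C@H]2CC[C@@]1(C)O` gives 10300 nM
Compound 2 `CC1=CC[C@H]2[C@H](CC[C@]2(C)O)C(C)(C)[C@@H]1CC[C@H]1[C@]2(C)CC[C@H](OC(=O)c3ccccc3F)C(C)(C)O[C@H]2CC[C@@]1(C)O` gives 28700 nM
Compound 3 `CC1=CC[C@H]2[C@H](CC[C@]2(C)O)C(C)(C)[C@@H]1CC[C@H]1[C@]2(C)CC[C@H](OC(=O)c3ccc(C(F)(F)F)c(F)c3)C(C)(C)O[C@H]2CC[C@@]1(C)O` gives 22200 nM

These results come from a functional assay on MDA-MB-231 cells (Homo sapiens) for antiproliferative activity, read by MTT assay, with a stated time of 72 h; on this read-out higher numbers stand for weaker inhibition and lower numbers for stronger inhibition. The three compounds share a core and differ only in the group on a carbonyl carbon. Compound 3 stands level with compound 2, given a 1.3-fold lower number from compound 2 to compound 3 (0.11 log units; within the scatter), while a 2.2-fold higher number from compound 1 to compound 3 (0.33 log units; beyond the scatter) sets it apart from compound 1. Compound 4 `CC1=CC[C@H]2[C@H](CC[C@]2(C)O)C(C)(C)[C@@H]1CC[C@H]1[C@]2(C)CC[C@H](OC(=O)c3ccco3)C(C)(C)O[C@H]2CC[C@@]1(C)O` carries furan-2-yl in place of 3-fluoro-4-(trifluoromethyl)phenyl on a carbonyl carbon, a swap counted as furan-2-yl in place of 3-fluoro-4-(trifluoromethyl)phenyl on a carbonyl carbon here. The closest evidence is the other swaps at this place, a 2.8-fold higher number from compound 1 to compound 2 (0.45 log units; beyond the scatter) and a 2.2-fold higher number from compound 1 to compound 3 (0.33 log units; beyond the scatter), both modest. Going by the values given here, no measured compound carries furan-2-yl, so uncertainty remains, in either direction. The expected result is a 1.1-fold lower number from compound 3 to compound 4 (0.05 log units; within the scatter), no step beyond the scatter. Compound 4 is estimated at 20000 nM, with an expected range of 8000 nM to 50000 nM.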

Compound 4, half-maximal inhibitory concentration: 14000 nM
The estimate for compound 4 lay 1.4-fold (0.15 log units) above the measured number; the range from low to high includes it.
By their numbers in this assay, from the lowest: compounds 1, 4, 3 and 2 (each within the scatter of the next, the first and the last beyond it).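

Furan-2-yl is the first group here on the carbonyl carbon that is not a substituted phenyl, and the change leaves the number level with two of the phenyl compounds (a 1.6-fold lower number from compound 3 to compound 4 (0.20 log units; within the scatter); a 1.4-fold higher number from compound 1 to compound 4 (0.13 log units; within the scatter)). Only the comparison with the 2-fluorophenyl compound goes beyond the scatter, and modestly (a 2.1-fold lower number from compound 2 to compound 4 (0.31 log units; beyond the scatter)). So among these four compounds, a phenyl ring is not needed to stay in this range.

No measurement shown explains these differences. Going by these compounds, how a pyridine ring, an amine or a longer alkyl chain would read out at this place remains open.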